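Chloro on the Phenyl Ring: From Thioether to Sulfone

The compounds below may be only part of what the source reports. "The series", "measured", "known", "first", "only" and "open" are said of these compounds alone.

Compound 1 `CC(O)(CSc1ccccc1)c1nc(-c2ccccc2)no1` carries a plain phenyl ring on its core. In a functional assay on DU-145 cells (Homo sapiens) for cytotoxicity, read by MTT assay (on this read-out higher numbers stand for weaker inhibition and lower numbers for stronger inhibition), compound 1 gives > 100000 nM, which is a limit of the assay rather than a number. Compound 2 `CC(O)(CSc1ccccc1)c1nc(-c2ccc(Cl)cc2)no1` differs from compound 1 by chloro in place of hydrogen on an aromatic carbon. In this assay compound 2 gives 4500 nM. Going by the values given here, the measured step of an at least 22-fold lower number from compound 1 to compound 2 (1.34 log units; beyond the scatter) is the only observation of this change so far.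

Compound 3 `CC(O)(CS(=O)(=O)c1ccc(F)cc1)c1nc(-c2ccccc2)no1` rests on a different core; the difference between the two cores is not broken down here. In this assay compound 3 gives > 100000 nM, again a limit of the assay. Two of the three values shown sit at the limit of > 100000 nM in this assay, at which 2 of the 3 values shown sit.

Among the compounds with values here, compound 4 `CC(O)(CS(=O)(=O)c1ccc(F)cc1)c1nc(-c2ccc(Cl)cc2)no1` differs from compound 3 by chloro in place of hydrogen on an aromatic carbon, the same change as the one from compound 1 to compound 2. A step of an at least 5.0-fold lower number from compound 3 to compound 4 (0.69 log units; beyond the scatter) is expected because an at least 22-fold lower number from compound 1 to compound 2 (1.34 log units; beyond the scatter) was large, though compound 3 starts from a limit, so the starting point is itself uncertain. For compound 4 the estimated value is 20000 nM, with an expected range from 4000 nM to 100000 nM.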

Compound 4, half-maximal inhibitory concentration: > 100000 nM
Compound 4 gave a limit, no number; the forecaster's own chance of this, stated with the estimate: 40%; middle value at least 5.0-fold (0.69 log units) from the limit.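

Going by these compounds alone, compound 3 and compound 4 both stop at a limit of this assay rather than at a number, so no step between them can be read: the limit of > 100000 nM in this assay, at which 3 of the 4 values shown sit. The compounds shown leave open whether chloro in place of hydrogen lowers the number at all on the core of compound 3, as it does on the core of compound 1.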